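The source may report more compounds than this note shows. Statements on the series, on what has been measured and on what is new or still open speak of the compounds shown alone.

Compound 1 `Cn1cnnc1SCC(=O)N/N=c1/scc(-c2ccc(C#N)cc2)n1-c1ccccc1` gives 153 ug/mL in an ADME assay on NIH3T3 cells (Mus musculus) for cytotoxicity, read by MTT assay, with a stated time of 24 h; on this read-out lower numbers stand for stronger inhibition and higher numbers for weaker inhibition.
Compound 2 `Cc1ccc(-c2cs/c(=N/NC(=O)CSc3ncccn3)n2-c2ccccc2)cc1` gives only a limit in this assay, > 500 ug/mL.
Compound 3 `Cn1cnnc1SCC(=O)N/N=c1/scc(-c2ccc([N+](=O)[O-])cc2)n1-c1ccccc1` gives 133 ug/mL in this assay.
Compound 4 `Cc1ccc(-c2cs/c(=N/NC(=O)CSc3nncn3C)n2-c2ccccc2)cc1` has not yet been measured in this assay.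

Among the measured compounds shown here, of the two numbers so far, compound 3 carries the lower one, but its nearest neighbour is compound 1, and the step of a 1.2-fold lower number from compound 1 to compound 3 (0.06 log units; within the scatter) is within the scatter, so the two cannot be ranked. The step to compound 4 is a change on the same aromatic carbon of the shared core: methyl in place of nitro on an aromatic carbon. For the measured compounds named here, the only measured step that touches this position is the one from compound 1 to compound 3, and it was too small to count; no measured step replaces nitro with methyl while the rest of compound 3 is kept. Compound 2, which carries the methyl but a different sulfur-linked heterocycle, sits at the limit (the limit of > 500 ug/mL in this assay, at which 1 of the 3 values shown sits), and that is the one hint pointing to a higher number. The expectation for compound 4 is therefore a modest step towards weaker inhibition, a 1.9-fold higher number from compound 3 to compound 4 (0.27 log units; within the scatter), with a real chance that only a limit is reported. The estimate for compound 4 in this assay is 250 ug/mL, between 110 ug/mL and 550 ug/mL.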

Compound 4, half-maximal inhibitory concentration: 130 ug/mL
Estimate against measurement, compound 4: 1.9-fold (0.28 log units) above, and the stated range covers the measured number.
By their numbers in this assay, from the lowest: compounds 4, 3 and 1 (each within the scatter of the next). At a limit, above all of these: compound 2.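

On the aromatic carbon of the six-membered ring, methyl, nitro and cyano cannot be told apart in this assay: the printed steps are a 1.0-fold lower number from compound 3 to compound 4 (0.01 log units; within the scatter) and a 1.2-fold lower number from compound 1 to compound 4 (0.07 log units; within the scatter), and both are too small to count. With the methyl kept on that ring, the group on the sulfur does make a real difference, and the result is an at least 3.8-fold lower number from compound 2 to compound 4 (0.58 log units; beyond the scatter) when 4-methyl-4H-1,2,4-triazol-3-yl stands in place of pyrimidin-2-yl, so the methyl alone does not account for the limit seen with compound 2. That step has only a lower bound, since compound 2 gives a limit and not a number: the limit of > 500 ug/mL in this assay, at which 1 of the 4 values shown sits.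

The compounds shown place no amine or carboxylic acid on this aromatic carbon, so it remains open whether such a group would shift the number in this assay when the three groups seen so far do not. Pyrimidin-2-yl on the sulfur also appears here only together with methyl on the ring, so it is unknown whether the same swap on the sulfur would matter with nitro or cyano in that place.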